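Removing the trifluoromethyl group: what to expect

A few compounds are considered here, and "the series" means these few. Any claim that something is new, unique, unknown or untested is made for them only; others in the source may bear on it.

Of the compounds shown here, three have been measured so far in an ADME assay on MRC5 cells (Homo sapiens) for inhibition, with a stated time of 72 h; on this read-out lower numbers stand for an effect already at smaller amounts and higher numbers for an effect only at larger amounts of compound. Compound 1 `COc1ccccc1C(=O)Nc1c[nH]nc1C(=O)N[C@H]1CC[C@H](OC)CC1` gives 1500 nM, compound 2 `CO[C@H]1CC[C@H](NC(=O)c2n[nH]cc2NC(=O)c2ccccc2C(F)(F)F)CC1` gives 3300 nM, and compound 3 `COc1cccc(OC)c1C(=O)Nc1c[nH]nc1C(=O)NC1CCN(Cc2ccccc2)C1` gives 38000 nM. Compound 2 therefore stands second highest of the three, nearest to compound 1 and furthest from compound 3.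

The new compound 4 `CO[C@H]1CC[C@H](NC(=O)c2n[nH]cc2NC(=O)c2ccccc2)CC1` differs from compound 2 by hydrogen in place of trifluoromethyl on an aromatic carbon. The change sits on an aromatic carbon of a six-membered aromatic ring of carbon only, ortho to a large group.

For the measured compounds named here, only one measured step touches this position: a 2.2-fold higher number from compound 1 to compound 2 (0.34 log units; beyond the scatter). It shows that exchanging the group there shifts the number by a modest amount in this assay. Nothing measured shows a hydrogen at that place, so the direction for compound 4 is uncertain; a modest step in either direction, or none beyond the scatter, seems possible. Because a 2.2-fold higher number from compound 1 to compound 2 (0.34 log units; beyond the scatter) already spans the range seen at this position, compound 4 is estimated to land near compound 2, with a step of a 1.3-fold lower number from compound 2 to compound 4 (0.12 log units; within the scatter). Compound 4 is therefore expected to give about 2500 nM, within a range of 900 nM to 7000 nM.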

Compound 4, half-maximal effective concentration: 800 nM
The estimate for compound 4 lay 3.1-fold (0.49 log units) above the measured number, and the stated range ends above it.
By their numbers in this assay, from the lowest: compounds 4 and 1 (each within the scatter of the next); then compound 2; then compound 3.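

With the hydrogen compound in hand, this assay shows the direction of this change: removing trifluoromethyl from this aromatic carbon gives a 4.1-fold lower number from compound 2 to compound 4 (0.62 log units; beyond the scatter), a step beyond the usual scatter. Hydrogen and methoxy, by contrast, cannot be told apart here, since a 1.9-fold lower number from compound 1 to compound 4 (0.27 log units; within the scatter) lies within the scatter, so among the three groups seen at this position, only trifluoromethyl stands out, with the higher number. The data offer no measurement that could explain this difference.

On these data alone, it remains open how other groups at this position would read, such as a chlorine atom, an amine or a carboxylic acid. For the compounds shown here, it is also open whether replacing trifluoromethyl with hydrogen would give a similar step in compounds carrying a different group on the other amide, such as the one in compound 3.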